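Swapping Chloro for Iodo on the Amide-Side Ring

The source may report more compounds than this note shows. Statements on the series, on what has been measured and on what is new or still open speak of the compounds shown alone.

Of the compounds shown here, three have been tested in a functional assay on HEK293 cells for agonist activity at probable G-protein coupled receptor 27 (Homo sapiens), read by a luciferase reporter and beta-arrestin recruitment, with a stated time of 10 min; a lower number here means that less compound is needed, a higher number that more compound is needed for the effect. Compound 1 `O=C(Nc1ccc(S(=O)(=O)Nc2cccc(Cl)c2)cc1)c1ccc(Cl)cc1Cl` gives 575 nM in this assay. Among the measured compounds shown here, compound 2 `O=C(Nc1ccc(S(=O)(=O)Nc2ccccc2Cl)cc1)c1ccc(Cl)cc1Cl` gives 1260 nM, and the one measured step, a 2.2-fold higher number from compound 1 to compound 2 (0.34 log units; beyond the scatter), moves the chloro group on the sulfonamide-side ring rather than anything on the amide-side ring. Compound 3 `O=C(Nc1ccc(S(=O)(=O)Nc2ccccc2)cc1)c1ccc(Cl)cc1F` gives 3980 nM, which is the highest of the three numbers, and its gaps to compound 2 and to compound 1 both lie beyond the scatter. Compound 3 differs from compound 2 in two places at once, so those two values alone do not separate what each change contributes.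

Compound 4 `O=C(Nc1ccc(S(=O)(=O)Nc2ccccc2)cc1)c1ccc(I)cc1F` is compound 3 with a single change: iodo in place of chloro on an aromatic carbon. For the measured compounds named here, no measured step exchanges one halogen for another at this position, and the only measured step concerns a different ring, so nothing among the tested compounds speaks directly to this swap. With no guide beyond that, the step in this assay is expected to be small, and it is estimated as a 1.3-fold lower number from compound 3 to compound 4 (0.12 log units; within the scatter), in no direction that can be argued from the data. Compound 4 is therefore estimated at 3000 nM, with a range from 1000 nM to 10000 nM.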

Compound 4, half-maximal effective concentration: 5130 nM
Beside the measured number, compound 4's estimate is 1.7-fold (0.23 log units) below it, within the range that was stated.
By their numbers in this assay, from the lowest: compound 1; then compound 2; then compounds 3 and 4 (each within the scatter of the next).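

In this assay, among the compounds shown here, the change from 4-chloro-2-fluorophenyl to 2-fluoro-4-iodophenyl gives a 1.3-fold higher number from compound 3 to compound 4 (0.11 log units; within the scatter) and is the first measured exchange of one halogen for another at this position, para to a large group and meta to a fluoro group. Iodo and chloro therefore cannot be told apart here, so a chlorine can give way to an iodine at this position with no difference beyond the usual scatter, something the earlier compounds could not show, as their only measured step moved a chloro group on the sulfonamide-side ring. No supporting measurement bears on this result, so no reason for it can be given.

As far as these compounds go, both compounds carry a halogen at this position, so it remains open whether an amine, a methoxy group or a carboxylic acid there would give a similar number in this assay or a very different one. From the compounds shown here alone, it is also open whether iodo and chloro would still read alike in compounds carrying a chloro group on the sulfonamide-side ring, as compound 1 and compound 2 do.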